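The compounds below may be only part of what the source reports. "The series", "measured", "known", "first", "only" and "open" are said of these compounds alone.

Measured compounds: compound 1 `CN1CCC[C@H]1COc1cccnc1`, compound 2 `CN1CCC[C@H]1COc1cncc(C#CCCCCF)c1`, compound 3 `CCCCC#Cc1cncc(OC[C@@H]2CCCN2C)c1`.

In an assay on a protein complex for binding affinity to Neuronal acetylcholine receptor; alpha3/beta4 (Rattus norvegicus) (on this read-out lower numbers stand for stronger inhibition and higher numbers for weaker inhibition), compound 1 gives 1400 nM. Compound 2 gives 88000 nM and compound 3 gives 40000 nM, so compound 3 stands second highest of the three; its nearest neighbour is compound 2, from which a 2.2-fold lower number from compound 2 to compound 3 (0.34 log units; beyond the scatter), and its furthest is compound 1, from which a 29-fold higher number from compound 1 to compound 3 (1.46 log units; beyond the scatter).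

Compound 4 `C#Cc1cncc(OC[C@@H]2CCCN2C)c1` has not yet been measured in this assay. It differs from compound 3 by hydrogen in place of butyl on a triple-bonded carbon. For the measured compounds named here, two measured steps bear on this. The step of a 29-fold higher number from compound 1 to compound 3 (1.46 log units; beyond the scatter) shows that hex-1-yn-1-yl in place of hydrogen on the aromatic carbon carries a large rise in the number. The step of a 2.2-fold lower number from compound 2 to compound 3 (0.34 log units; beyond the scatter) shows that a change at the far end of the chain, fluoro to hydrogen, carries a modest fall. Compound 4 carries ethynyl where compound 3 carries hex-1-yn-1-yl and compound 1 carries hydrogen, so compound 4 is expected to fall between compound 3 and compound 1, with a step of a 6.7-fold lower number from compound 3 to compound 4 (0.82 log units; beyond the scatter) expected to be beyond the scatter. Compound 4 is estimated at 6000 nM, in a range from 1500 nM to 25000 nM.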

Compound 4, inhibition constant: 6800 nM
Estimate against measurement, compound 4: 1.1-fold (0.05 log units) below, and the stated range covers the measured number.
By their numbers in this assay, from the lowest: compound 1; then compound 4; then compound 3; then compound 2.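

In this assay, hydrogen in place of butyl on the triple-bonded carbon gives a 5.9-fold lower number from compound 3 to compound 4 (0.77 log units; beyond the scatter), so the chain beyond the alkyne accounts for part of the rise seen with hex-1-yn-1-yl. The alkyne unit itself is not neutral: ethynyl in place of hydrogen on the aromatic carbon still gives a 4.9-fold higher number from compound 1 to compound 4 (0.69 log units; beyond the scatter), and the step for removing 4-fluorobutyl is larger, at a 13-fold lower number from compound 2 to compound 4 (1.11 log units; beyond the scatter). Nothing measured here explains these steps.

The compounds shown leave open how the number moves with a shorter chain, such as methyl or ethyl, on the triple-bonded carbon. They also leave open whether a group without a triple bond on the aromatic carbon, such as bromo or phenyl, would stay closer to compound 1.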